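The compounds below may be only part of what the source reports. "The series", "measured", "known", "first", "only" and "open" are said of these compounds alone.

In a functional assay on HeLa cells (Homo sapiens) for antiproliferative activity, read by MTT assay, with a stated time of 72 h (a higher number here means a weaker inhibitor, a lower number a stronger inhibitor), compound 1 `Nc1nc(N)c2cc(CSC(=S)N3CCN(C4CCCCC4)CC3)ccc2n1` gives 5960 nM, compound 2 `Nc1nc(N)c2cc(CSC(=S)N3CCN(c4ccc(O)cc4)CC3)ccc2n1` gives 5180 nM and compound 3 `Nc1nc(N)c2cc(CSC(=S)N3CCN(c4ccc(Cl)cc4)CC3)ccc2n1` gives 6990 nM, so compound 3 stands level with both others. The steps among the three are a 1.2-fold lower number from compound 1 to compound 2 (0.06 log units; within the scatter), a 1.2-fold higher number from compound 1 to compound 3 (0.07 log units; within the scatter) and a 1.3-fold higher number from compound 2 to compound 3 (0.13 log units; within the scatter). Compound 4 `CC(=O)c1ccc(N2CCN(C(=S)SCc3ccc4nc(N)nc(N)c4c3)CC2)cc1` carries acetyl in place of chloro on an aromatic carbon. The nearest evidence is the exchange of hydroxy for chloro on that carbon, a 1.3-fold higher number from compound 2 to compound 3 (0.13 log units; within the scatter), so no step beyond the scatter is expected in this assay. The expected step is a 1.2-fold lower number from compound 3 to compound 4 (0.07 log units; within the scatter). The estimate for compound 4 is 6000 nM, with an expected range from 2800 nM to 12000 nM.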

Compound 4, half-maximal inhibitory concentration: 2040 nM
Estimate against measurement, compound 4: 2.9-fold (0.47 log units) above; measured number below the stated range.
By their numbers in this assay, from the lowest: compound 4; then compounds 2, 1 and 3 (each within the scatter of the next).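

In this assay, among these compounds, acetyl is the first group on this aromatic carbon, para to a large group, to take the number beyond the scatter, with a 3.4-fold lower number from compound 3 to compound 4 (0.53 log units; beyond the scatter) and a 2.5-fold lower number from compound 2 to compound 4 (0.40 log units; beyond the scatter) against the exchange of hydroxy for chloro, which stayed within it. The 4-acetylphenyl group also stands apart from cyclohexyl on the ring nitrogen, with a 2.9-fold lower number from compound 1 to compound 4 (0.47 log units; beyond the scatter) where neither other aryl group did. Nothing measured here explains this difference. From the compounds shown here alone, whether a nitrile, a methyl ester or a carboxylic acid on this carbon would move the number likewise stays open.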